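Urea aryl swap on a pyrazole series, cell growth read-out

The source may report more compounds than this note shows. Statements on the series, on what has been measured and on what is new or still open speak of the compounds shown alone.

Compound 1 `COc1cc(Cl)cc(-c2nn(-c3cccc(NC(=O)Nc4cccc(C(F)(F)F)c4)c3)cc2-c2ccncc2)c1` gives -41% in a functional assay on HOP-62 cells (Homo sapiens) for inhibition, read by sulforhodamine B assay, with a stated time of 48 h, tested at 100 uM (a higher number here means a weaker effect of the compound at the concentration tested, a lower number a stronger effect), the lowest of the two numbers at hand. Compound 2 `O=C(Nc1cccc(-n2cc(-c3ccncc3)c(-c3cc(O)cc(Cl)c3)n2)c1)Nc1ccc(Cl)c(Cl)c1` gives -3% in this assay; it differs from compound 1 in more than one place, so the pair only shows its two values. Compound 3 `COc1cc(Cl)cc(-c2nn(-c3cccc(NC(=O)Nc4ccc(Cl)c(Cl)c4)c3)cc2-c2ccncc2)c1` carries the change (3,4-dichlorophenyl in place of 3-(trifluoromethyl)phenyl on an amide-type nitrogen). Within the data shown here, no single-point step is available to size this change. Because compound 2, which also carries 3,4-dichlorophenyl, gives -3%, a weakening beyond the scatter is expected. Compound 3 is estimated at -20% (range -45% to 5%), a step of a number 21 percentage points higher from compound 1 to compound 3 (beyond the scatter) expected.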

Compound 3, a percentage reported as activity, at one concentration (the size of the read-out at that concentration, not a potency): 12%
For compound 3 the middle estimate is 32 percentage points below the measured one; the whole stated range lies below it.
By their numbers in this assay, from the lowest: compound 1; then compound 2; then compound 3.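

In this assay the group on the amide-type nitrogen now has a sized effect: 3,4-dichlorophenyl in place of 3-(trifluoromethyl)phenyl gives a large weakening (a number 53 percentage points higher from compound 1 to compound 3 (beyond the scatter)). With 3,4-dichlorophenyl held, the oxygen on the aromatic ring also matters, since methyl in place of hydrogen there gives a modest step toward a weaker effect (a number 15 percentage points higher from compound 2 to compound 3 (beyond the scatter)). Nothing at hand bears on the cause of either step.

Open, from the compounds shown here alone, is how a carboxylic acid or an amine on the phenyl at the amide-type nitrogen would read. Also open, going by these compounds, is whether ethyl on that oxygen extends the methyl step.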